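A few compounds are considered here, and "the series" means these few. Any claim that something is new, unique, unknown or untested is made for them only; others in the source may bear on it.

Compound 1 `Cc1cccc(Nc2nc(-c3ccncc3)c(C)s2)c1`: 10000 nM
Compound 2 `Clc1ccccc1Nc1nc(-c2ccncc2)cs1`: 28200 nM

Among the measured compounds shown here, in a functional assay on RCC4 cells (Homo sapiens) for inhibition, read by XTT assay, with a stated time of 4 days (a lower number here means a stronger inhibitor, a higher number a weaker inhibitor), compound 2 gives 28200 nM, the higher of the two numbers so far, while compound 1 gives 10000 nM, a gap beyond the usual scatter. Compound 3 `Fc1ccccc1Nc1nc(-c2ccncc2)cs1` differs from compound 2 by fluoro in place of chloro on an aromatic carbon. For the measured compounds named here, no measured pair shows this same change, so the size of the step is uncertain. The step of a 1.3-fold lower number from compound 2 to compound 3 (0.11 log units; within the scatter) is the estimated change, expected to be small and of uncertain direction. Compound 3 is therefore estimated at about 22000 nM, within 7000 nM to 60000 nM.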

Compound 3, half-maximal inhibitory concentration: 14500 nM
For compound 3 the middle estimate is 1.5-fold (0.18 log units) above the measured one; the measured number falls inside the stated range.
By their numbers in this assay, from the lowest: compounds 1, 3 and 2 (each within the scatter of the next, the first and the last beyond it).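

In this assay, fluoro in place of chloro on an aromatic carbon, ortho to a large group, gives a 1.9-fold lower number from compound 2 to compound 3 (0.29 log units; within the scatter). Among the compounds shown here, this is the first step that can be read between two compounds differing in one place, and it does not separate the two halogens at this position. No measured evidence offers a reason for this result.

Still open, from the compounds shown here alone, is whether another group at this place, such as methoxy, an amine or a carboxylic acid, would give a step beyond the scatter. Also open, going by these compounds, is what this same change does elsewhere on the aromatic ring.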